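This account rests on a few compounds, and the source may have more. Where it says the series, first, only, none or still open, it means among the compounds named here.

Compound 1 `S=C(Nc1ccccc1)N1N=C(c2ccc(Cl)cc2)CC1c1ccc2c(c1)OCCO2` was tested in a functional assay on HCT-116 cells (Homo sapiens) for antiproliferative activity, read by MTT assay, with a stated time of 48 h; a higher number here means a weaker inhibitor of growth, a lower number a stronger inhibitor of growth. In this assay compound 1 gives > 200000 nM, which is a limit of the assay and not a number, since compound 1 sits at the limit of > 200000 nM in this assay, at which 1 of the 3 values shown sits. Compound 2 `S=C(Nc1ccccc1)N1N=C(c2cccc(Cl)c2)CC1c1ccc2c(c1)OCCO2` gives 138000 nM in this assay, and compound 3 `S=C(Nc1ccccc1)N1N=C(c2ccc(Cl)c(Cl)c2)CC1c1ccc2c(c1)OCCO2` gives 125000 nM. The steps of an at least 1.4-fold lower number from compound 1 to compound 2 (0.16 log units; that floor lies within the scatter) and an at least 1.6-fold lower number from compound 1 to compound 3 (0.20 log units; that floor lies within the scatter) change the same ring that carries the chloro group of compound 1, and each is only a floor; the step of a 1.1-fold lower number from compound 2 to compound 3 (0.04 log units; within the scatter) is small. Compound 4 `S=C(Nc1ccccc1)N1N=C(c2ccc(OCc3ccccc3)cc2)CC1c1ccc2c(c1)OCCO2` differs from compound 1 by benzyloxy in place of chloro on an aromatic carbon. For the measured compounds named here, no measured step exchanges chloro for benzyloxy, so the measured steps give only a loose guide, and all three compounds are weak. Compound 4 is therefore expected to stay in the same weak region, a step of an at least 1.3-fold lower number from compound 1 to compound 4 (0.12 log units; that floor lies within the scatter). Compound 4 is estimated at 150000 nM, between 50000 nM and 400000 nM.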

Compound 4, concentration for 50% growth inhibition: 8530 nM
Beside the measured number, compound 4's estimate is 18-fold (1.25 log units) above it, and the stated range ends above it.
By their numbers in this assay, from the lowest: compound 4; then compounds 3 and 2 (each within the scatter of the next). At a limit, above all of these: compound 1.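

In this assay, benzyloxy in place of chloro gives an at least 23-fold lower number from compound 1 to compound 4 (1.37 log units; beyond the scatter), so a change at this position, para to a large group, can move growth inhibition well beyond the scatter, which the steps to compound 2 and compound 3 did not show. Compound 1 stands at a limit of the assay and not a number: the limit of > 200000 nM in this assay, at which 1 of the 4 values shown sits.

The compounds shown leave open whether the oxygen or the added aromatic ring of benzyloxy goes with this step. A methoxy group or a phenyl group at this position would help to tell these apart.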